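Working notes: trifluoromethyl analogue of compound 2

This account rests on a few compounds, and the source may have more. Where it says the series, first, only, none or still open, it means among the compounds named here.

Compound 2 `CCCc1cc(NNC(=O)Nc2cc(Cl)nc(Cl)c2)nc2c1cnn2C` holds the lowest of the two numbers obtained so far in an assay on isolated protein for binding affinity to sphingosine 1-phosphate receptor 2 (Homo sapiens), read by surface plasmon resonance (on this read-out lower numbers stand for tighter binding and higher numbers for weaker binding), giving 1400 nM. Its nearest neighbour is compound 1 `CCCc1cc(NNC(=O)Nc2cc(Cl)nc(Cl)c2)nc2c1c(C)nn2C`, which in this assay gives 2360 nM; the step of a 1.7-fold lower number from compound 1 to compound 2 (0.23 log units; within the scatter) lies within the scatter, so the two compounds cannot be ordered on this read-out. Compound 3 `CCCc1cc(NNC(=O)Nc2cc(Cl)nc(Cl)c2)nc2c1c(C(F)(F)F)nn2C` has not yet been measured. It differs from compound 2 by trifluoromethyl in place of hydrogen on an aromatic carbon. Among the measured compounds shown here, the only measured step that bears on this change is a 1.7-fold lower number from compound 1 to compound 2 (0.23 log units; within the scatter), which was small. For the measured compounds named here, the single change seen so far on this aromatic carbon left the number essentially unchanged, and the same is expected here, with at most a slight drift towards the higher number of compound 1. Compound 3 is therefore expected to give 2000 nM, in the range 700 nM to 6000 nM. The step of a 1.4-fold higher number from compound 2 to compound 3 (0.15 log units; within the scatter) is expected to stay within the scatter.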

Compound 3, dissociation constant: 890 nM
Compound 3: middle estimate off by 2.2-fold (0.35 log units), on the high side; the range from low to high includes it.
By their numbers in this assay, from the lowest: compounds 3, 2 and 1 (each within the scatter of the next, the first and the last beyond it).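

In this assay this aromatic carbon now carries hydrogen, methyl or trifluoromethyl, and the step of a 1.6-fold lower number from compound 2 to compound 3 (0.20 log units; within the scatter) shows that trifluoromethyl in place of hydrogen, like methyl in place of hydrogen, cannot be told apart from the hydrogen compound on this read-out. Among the compounds shown here, the step of a 2.7-fold lower number from compound 1 to compound 3 (0.42 log units; beyond the scatter) is the first to pass the scatter, so methyl and trifluoromethyl on this carbon can be ordered, with compound 3 on the tighter-binding side of compound 1, even though compound 2 separates from neither. Nothing measured here speaks to the origin of this modest gap.

Open, on these data alone, is how an ethyl group, a chlorine atom or a nitrile on this aromatic carbon would stand against compound 2 and compound 3. Equally open, as far as these compounds go, is whether trifluoromethyl in place of methyl gives a step of similar size when other parts of the shared core change.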